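The compounds below may be only part of what the source reports. "The series", "measured", "known", "first", "only" and "open" are said of these compounds alone.

Measured compounds:
Compound 1 `COc1ccc(S(=O)(=O)N2CCc3cccc(NC(=O)c4ccc(C#N)cc4)c32)cc1` gives 89 nM in a functional assay on MKN-45 cells (Homo sapiens) for cytotoxicity; on this read-out higher numbers stand for weaker inhibition and lower numbers for stronger inhibition.
Compound 2 `COc1ccc(S(=O)(=O)N2CCc3cccc(NS(=O)(=O)c4ccc([N+](=O)[O-])cc4)c32)cc1` gives 933 nM in this assay.

For the measured compounds named here, compound 1 holds the lower of the two numbers; compound 2 sits at a markedly higher number, and the gap between the two is beyond the scatter, though no single step between them is drawn here, so the two figures are simply set side by side. Compound 3 `COC(=O)c1ccc(C(=O)Nc2cccc3c2N(S(=O)(=O)c2ccc(OC)cc2)CC3)cc1` has not yet been measured in this assay. It is reached from compound 1 by one change (methoxycarbonyl in place of cyano on an aromatic carbon). Going by the values given here, nothing among the measured compounds tests this exchange, so the expectation rests on the closeness of the two structures. The step of a 1.5-fold higher number from compound 1 to compound 3 (0.16 log units; within the scatter) is expected to be small, within the scatter, with no clear direction. Compound 3 is therefore estimated at 130 nM, in a range from 40 nM to 400 nM.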

Compound 3, half-maximal inhibitory concentration: 312 nM
The estimate for compound 3 lay 2.4-fold (0.38 log units) below the measured number; the measured number falls inside the stated range.
By their numbers in this assay, from the lowest: compound 1; then compound 3; then compound 2.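

For the compounds shown here, compound 1 and compound 3 form the first measured pair that differs in one place, and they show that this position on the aromatic ring, para to a large group, is sensitive to the group it carries. In this assay, replacing cyano with methoxycarbonyl gives a 3.5-fold higher number from compound 1 to compound 3 (0.54 log units; beyond the scatter), a modest step but one that goes beyond the scatter. The shared core and the amide link are unchanged, so the step belongs to this single exchange, but no measurement shown here explains its direction or size.

As far as these compounds go, only cyano and methoxycarbonyl are compared at this position, so it remains open how a carboxylic acid, a primary amide or a plain hydrogen would read there. From the compounds shown here alone, it is also open whether the same exchange would give a similar step on a different core.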